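The compounds below may be only part of what the source reports. "The series", "measured", "known", "first", "only" and "open" are said of these compounds alone.

In an ADME assay on THP-1 cells (Homo sapiens) for cytotoxicity, read by resazurin assay, with a stated time of 72 h (on this read-out higher numbers stand for lower toxicity in this test and lower numbers for higher toxicity in this test), compound 1 (`CCCCc1ccc(C(=O)/C=C/c2ccc([N+](=O)[O-])o2)cc1`) gives 48700 nM and compound 2 (`CC(C)(C)c1ccc(C(=O)/C=C/c2ccc([N+](=O)[O-])s2)cc1`) gives 8400 nM as the lowest of the two numbers, a gap beyond the usual scatter. Compound 2 therefore stands as the more toxic of the two in this test. Among the compounds with values here, no step between measured compounds that differ in one place is available. Compound 3 (`CSc1ccc(C(=O)/C=C/c2ccc([N+](=O)[O-])s2)cc1`) differs from compound 2 by methylsulfanyl in place of tert-butyl on an aromatic carbon, para to a large group (methylsulfanyl in place of tert-butyl on an aromatic carbon). Nothing measured isolates this change, so the expectation in this assay rests on the two numbers alone: no step beyond the scatter is expected, and no direction is favoured. The estimated step of a 1.1-fold higher number from compound 2 to compound 3 (0.03 log units; within the scatter) is accordingly small. Compound 3 is expected at 9000 nM in this estimate, with an estimated range of 3000 nM to 27000 nM around it.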

Compound 3, half-maximal cytotoxic concentration: 8560 nM
Beside the measured number, compound 3's estimate is 1.1-fold (0.02 log units) above it, within the range that was stated.
By their numbers in this assay, from the lowest: compounds 2 and 3 (each within the scatter of the next); then compound 1.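

In this assay, within the data shown here, the first pair that differs in one place gives a 1.0-fold higher number from compound 2 to compound 3 (0.01 log units; within the scatter), so the two numbers cannot be told apart. Among these compounds, on this aromatic carbon, para to a large group, tert-butyl with its 4 heavy atoms and methylsulfanyl with its 2 heavy atoms, one of them sulfur, therefore give the same reading within the scatter, a comparison that the earlier compounds could not offer. No measurement is available that would explain this result.

The compounds shown leave open whether an amine, a carboxylic acid or a longer chain on this aromatic carbon would also stay within the scatter of compound 2. They also leave open whether methylsulfanyl would give a similarly small step on the core of compound 1.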